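Trifluoroacetamide replacing the dimethylglycinamide on the shared core

The compounds below may be only part of what the source reports. "The series", "measured", "known", "first", "only" and "open" are said of these compounds alone.

Measured so far:
compound 1 `Cc1nc(N)sc1S(=O)(=O)Nc1ccc(Cc2nc3c([nH]2)c(=O)n(Cc2ccccc2F)c(=O)n3CC2CC2)cc1` — 230 nM
compound 2 `CN(C)CC(=O)Nc1ccc(Cc2nc3c([nH]2)c(=O)n(Cc2ccccc2F)c(=O)n3CC2CC2)cc1` — 2070 nM

In an assay on isolated protein for inhibition of phosphoenolpyruvate carboxykinase, cytosolic [GTP] (Homo sapiens) (on this read-out lower numbers stand for stronger inhibition and higher numbers for weaker inhibition), compound 2 gives the higher of the two numbers, standing apart from compound 1 by a 9.0-fold higher number from compound 1 to compound 2 (0.95 log units; beyond the scatter). Compound 3 `O=C(Nc1ccc(Cc2nc3c([nH]2)c(=O)n(Cc2ccccc2F)c(=O)n3CC2CC2)cc1)C(F)(F)F` carries the change (trifluoromethyl in place of (dimethylamino)methyl on a carbonyl carbon). For the measured compounds named here, no measured step touches this position; the single known step concerns the group on the aromatic nitrogen and so gives no direct guide. With nothing to lean on, compound 3 is expected to stay close to compound 2, with a 1.2-fold lower number from compound 2 to compound 3 (0.06 log units; within the scatter) as the estimated step. Compound 3 is therefore estimated at 1800 nM in this assay, within 500 nM to 6500 nM.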

Compound 3, half-maximal inhibitory concentration: 1800 nM
The estimate for compound 3 equals the measured number at the digits printed; measured number inside the range.
By their numbers in this assay, from the lowest: compound 1; then compounds 3 and 2 (each within the scatter of the next).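

In this assay, trifluoromethyl and (dimethylamino)methyl on the carbonyl carbon cannot be told apart, with a 1.2-fold lower number from compound 2 to compound 3 (0.06 log units; within the scatter), so removing the amine nitrogen and its hydrogen-bond acceptor leaves the number within the scatter. The gap to the sulfonyl group remains, with a 7.8-fold higher number from compound 1 to compound 3 (0.89 log units; beyond the scatter), so it is seen with both amides. No available evidence explains either step.

On these data alone, whether a carboxylic acid or a longer alkyl chain on the carbonyl carbon would change the number remains open. A methylsulfonyl group on the aromatic nitrogen would be needed to separate the sulfonyl from the 2-amino-4-methyl-1,3-thiazol-5-yl part.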